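A few compounds are considered here, and "the series" means these few. Any claim that something is new, unique, unknown or untested is made for them only; others in the source may bear on it.

Among the compounds with values here, in a functional assay on HepG2 cells (Homo sapiens) for antiproliferative activity, read by MTT assay, with a stated time of 48 h (a lower number here means a stronger inhibitor, a higher number a weaker inhibitor), compound 1 (`COc1ccc(-c2ccc3c(c2)C(=O)C(=O)N3)cc1`) gives 960 nM and compound 2 (`COc1ccc(-c2ccc3c(c2)C(=O)C(=O)N3Cc2ccc(Cl)cc2)cc1`) gives 250 nM as the lowest of the two numbers so far. Compound 3 (`COc1ccc(-c2ccc3c(c2)C(=O)C(=O)N3Cc2cccc(Cl)c2)cc1`) is not yet measured. It has the same atoms as compound 2 joined differently, with 3-chlorophenyl in place of 4-chlorophenyl on a saturated chain carbon bound to an amide-type nitrogen in a ring. Within the data shown here, only one measured step bears on this, and only indirectly (a 3.8-fold lower number from compound 1 to compound 2 (0.58 log units; beyond the scatter)) with 4-chlorobenzyl in place of hydrogen on an amide-type nitrogen in a ring. Among the measured compounds shown here, no measured pair compares 4-chlorobenzyl with 3-chlorobenzyl, but the modest size of that step sets the expectation of a smaller move here. In this assay no step beyond the scatter is expected, and no direction is firmly expected, the estimate being (a 1.2-fold higher number from compound 2 to compound 3 (0.08 log units; within the scatter)) for this change. Compound 3 is estimated at 300 nM (expected range 120 nM to 750 nM).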

Compound 3, half-maximal inhibitory concentration: 320 nM
Compound 3: the middle estimate sits 1.1-fold (0.03 log units) below what was measured; the measured number falls inside the stated range.
By their numbers in this assay, from the lowest: compounds 2 and 3 (each within the scatter of the next); then compound 1.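

In this assay, 3-chlorobenzyl in place of 4-chlorobenzyl on the amide-type nitrogen in a ring gives a 1.3-fold higher number from compound 2 to compound 3 (0.11 log units; within the scatter), so the measured numbers do not separate these two groups at this position. Against the unsubstituted nitrogen, 3-chlorobenzyl in place of hydrogen gives a 3.0-fold lower number from compound 1 to compound 3 (0.48 log units; beyond the scatter), so the step beyond the scatter seen earlier with 4-chlorobenzyl is not confined to that one group. No supporting measurement bears on why the two chlorobenzyl groups read alike.

As far as these compounds go, it remains open whether the step from hydrogen belongs to the chlorine or to the benzyl group, a question that plain benzyl on this nitrogen would address. From the compounds shown here alone, how 2-chlorobenzyl or a longer chain such as 2-phenylethyl would compare with these two groups also remains open.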